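The source may report more compounds than this note shows. Statements on the series, on what has been measured and on what is new or still open speak of the compounds shown alone.

In a functional assay on M21 cells (Homo sapiens) for inhibition, read by sulforhodamine B assay, with a stated time of 48 h (a lower number here means a stronger inhibitor of growth, a higher number a weaker inhibitor of growth), compound 1 (`O=C(CCl)NC(=O)Nc1ccc(OC2CCCC2)cc1`) gives 2900 nM and compound 2 (`O=C(CCl)NC(=O)Nc1ccc(Oc2ccccc2)cc1`) gives 4200 nM. For the measured compounds named here, only these two numbers exist so far, and they lie within the usual scatter of each other, so compound 2 cannot be ranked against the only other measured compound.

The next compound, compound 3 (`O=C(CCl)NC(=O)Nc1ccc(I)cc1`), has iodo in place of phenoxy on an aromatic carbon, para to a group of 8 heavy atoms: iodo in place of phenoxy on an aromatic carbon. Going by the values given here, only one measured step bears on this change, and it bears only loosely: a 1.4-fold higher number from compound 1 to compound 2 (0.16 log units; within the scatter). That step stayed within the scatter, but it kept the oxygen on the aromatic ring and swapped only the group attached to it. Here the whole phenoxy leaves, and no measured compound shows what such a loss does. No step beyond the scatter is therefore expected, though with little confidence. The estimated step is a 1.1-fold lower number from compound 2 to compound 3 (0.02 log units; within the scatter). Compound 3 is expected at 4000 nM, with an estimated range of 1500 nM to 11000 nM.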

Compound 3, concentration for 50% growth inhibition: 4200 nM
The estimate for compound 3 lay 1.1-fold (0.02 log units) below the measured number; measured number inside the range.
By their numbers in this assay, from the lowest: compounds 1, 2 and 3 (each within the scatter of the next).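

In this assay, iodo in place of phenoxy gives no change at the digits printed from compound 2 to compound 3 (within the scatter), and iodo in place of cyclopentyloxy gives a 1.4-fold higher number from compound 1 to compound 3 (0.16 log units; within the scatter). The earlier step changed only the group attached to the oxygen, whereas these steps remove the oxygen as well, showing that in these three compounds neither that oxygen nor a ring attached through it is needed to keep the number within the scatter. A single iodine atom on this aromatic carbon therefore reads the same, within the scatter, as either of the much larger groups, but no supporting measurement is available to explain this match.

Since all three compounds lie within the scatter of one another, the compounds shown do not reveal any group at this position that moves the number beyond the scatter, and it remains open whether an amine, a carboxylic acid or a longer chain would do so. As far as these compounds go, the chlorine on the shared core is also present in all three compounds, so what happens to the number when it is replaced remains unknown.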